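From ethoxy to isopropoxy on a shared core

The source may hold more compounds than are shown below. What is called first, only, known or untested is meant among the compounds shown, and "the series" means these compounds.

Measured so far in a functional assay on Jurkat cells (Homo sapiens) for antiproliferative activity, read by MTT assay, with a stated time of 72 h; on this read-out lower numbers stand for stronger inhibition and higher numbers for weaker inhibition:
Compound 1 `COc1cc(-n2ncnc2-c2ccc(OC(F)(F)F)cc2)cc(OC)c1OC` gives > 10000 nM (a limit of the assay)
Compound 2 `CCOc1ccc(-c2ncnn2-c2cc(OC)c(OC)c(OC)c2)cc1` gives 5 nM

For the measured compounds named here, compound 2 holds the only actual number so far, since the value of compound 1 is a limit, so it cannot yet be ranked against a series. Going by the values given here, the one measured step is an at least 2000-fold lower number from compound 1 to compound 2 (3.30 log units; beyond the scatter) and it came with ethyl in place of trifluoromethyl on an oxygen on an aromatic ring.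

Compound 3 `COc1cc(-n2ncnc2-c2ccc(OC(C)C)cc2)cc(OC)c1OC` has not been measured and changes the group on that same oxygen: methyl in place of hydrogen on a saturated chain carbon bound to an oxygen on an aromatic ring and a saturated chain carbon which turns ethoxy into isopropoxy. The measured step, an at least 2000-fold lower number from compound 1 to compound 2 (3.30 log units; beyond the scatter) shows that the group on this oxygen can matter greatly, though it involved a different change from this single added methyl. A smaller step towards a higher number is therefore expected, and the estimated change in this assay is a 6.0-fold higher number from compound 2 to compound 3 (0.78 log units; beyond the scatter) with wide uncertainty. For compound 3 the estimate is 30 nM (expected range 6 nM to 250 nM).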

Compound 3, half-maximal inhibitory concentration: 650 nM
Compound 3: middle estimate off by 22-fold (1.34 log units), on the low side; measured number above the stated range.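

In this assay, a single added methyl that turns ethoxy into isopropoxy gives a 130-fold higher number from compound 2 to compound 3 (2.11 log units; beyond the scatter), so this position responds strongly even to a small change within the saturated chain on the oxygen, something the earlier exchange of ethyl for trifluoromethyl could not show. Isopropyl in place of trifluoromethyl still leaves an at least 15-fold lower number from compound 1 to compound 3 (1.18 log units; beyond the scatter), which places the three groups on this oxygen in an order: ethoxy gives the lowest number, isopropoxy a middle one and trifluoromethoxy the highest. The step involving compound 1 is only a bound, as one end of it is a limit and not a number: the limit of > 10000 nM in this assay, at which 1 of the 3 values shown sits.

The compounds shown leave open whether a straight propoxy chain on this oxygen would behave like ethoxy or like isopropoxy, and whether a smaller methoxy group or a free hydroxyl would give a number lower or higher than that of ethoxy. They also give no measured basis for saying why one added methyl changes the number by so much.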